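Working notes: removing one trifluoromethyl group

The source may hold more compounds than are shown below. What is called first, only, known or untested is meant among the compounds shown, and "the series" means these compounds.

- compound 1 `COc1cc(-c2nn(-c3cccc(NC(=O)Nc4cc(C(F)(F)F)cc(C(F)(F)F)c4)c3)cc2-c2ccncc2)ccc1Cl`: 307 nM
- compound 2 `COc1cc(-c2nn(-c3cccc(NC(=O)Nc4ccc(Cl)c(Cl)c4)c3)cc2-c2ccncc2)ccc1Cl`: 388 nM

Both values come from a functional assay on RPMI-8226 cells (Homo sapiens) for inhibition, read by sulforhodamine B assay, with a stated time of 48 h; a lower number here means a stronger inhibitor of growth, a higher number a weaker inhibitor of growth. Compound 1, at 307 nM, and compound 2, at 388 nM, lie within the usual scatter of each other, so these data do not separate them. Compound 3 `COc1cc(-c2nn(-c3cccc(NC(=O)Nc4cccc(C(F)(F)F)c4)c3)cc2-c2ccncc2)ccc1Cl` is not yet measured. It differs from compound 1 in one place, with hydrogen in place of trifluoromethyl on an aromatic carbon. Among the measured compounds shown here, no measured pair shows this change, so the expectation is tentative and leans only on the level set by compound 1 at 307 nM. The expected step of a 1.8-fold higher number from compound 1 to compound 3 (0.25 log units; within the scatter) is modest and points to a higher number, a weaker inhibitor of growth, though a result within the scatter would not surprise. For compound 3 the estimated value is 550 nM, with an expected range of 220 nM to 1500 nM.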

Compound 3, concentration for 50% growth inhibition: 340 nM
The estimate for compound 3 lay 1.6-fold (0.21 log units) above the measured number, within the range that was stated.
By their numbers in this assay, from the lowest: compounds 1, 3 and 2 (each within the scatter of the next).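

In this assay, hydrogen in place of trifluoromethyl on the aromatic carbon gives a 1.1-fold higher number from compound 1 to compound 3 (0.04 log units; within the scatter), so in these data the second trifluoromethyl group is not required to stay at the level of compound 1. The other single-place comparison, 3-(trifluoromethyl)phenyl in place of 3,4-dichlorophenyl on the amide-type nitrogen, gives a 1.1-fold lower number from compound 2 to compound 3 (0.06 log units; within the scatter), so all three substitution patterns on this ring read alike within the scatter. Nothing available here offers an explanation for this lack of separation.

Going by these compounds, whether this position tolerates groups unlike trifluoromethyl and hydrogen, such as an amine or a carboxylic acid, remains open. Also open, on these data alone, is whether the level holds when the remaining trifluoromethyl group gives way to hydrogen, leaving a plain phenyl ring.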